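The compounds below may be only part of what the source reports. "The series", "measured", "known", "first", "only" and "open" are said of these compounds alone.

The measured compounds:
compound 1 `CN(c1ccccc1)c1nc2cc(-c3ccc4c(ccn4C)c3)ccc2o1`, which in an assay on HEK293 cells for inhibition of Fatty-acid amide hydrolase 1 (Homo sapiens), read by fluorescence (a higher number here means a weaker inhibitor, a lower number a stronger inhibitor), gives 68 nM
compound 2 `COc1ccc(Nc2nc3cc(-c4ccc5c(ccn5C)c4)ccc3o2)cc1`, which in this assay gives 280 nM

Among the measured compounds shown here, compound 2 stands at the higher of the two numbers; its only neighbour is compound 1, and the step between them, a 4.1-fold higher number from compound 1 to compound 2 (0.61 log units; beyond the scatter), is the sole measured step in the set. Compound 3 `Cn1ccc2cc(-c3ccc4oc(Nc5ccccn5)nc4c3)ccc21` is the next compound to be measured. It differs from compound 2 in one place: pyridin-2-yl in place of 4-methoxyphenyl on a nitrogen on an aromatic ring.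

For the measured compounds named here, the one measured step bears on this change only loosely. It alters both what sits on the nitrogen attached to the shared core and whether that nitrogen carries a methyl or a hydrogen, so it does not isolate the exchange of one aromatic ring on the nitrogen for another. Going by the values given here, no measured pair shows a ring of carbon only replaced by a ring with one hetero atom at this position. With nothing to point firmly in either direction, compound 3 is expected to stay close to compound 2 in this assay, the estimated step of a 1.1-fold higher number from compound 2 to compound 3 (0.03 log units; within the scatter) lying within the usual scatter. For compound 3 the estimate in this assay is therefore 300 nM, with a range from 100 nM to 900 nM.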

Compound 3, half-maximal inhibitory concentration: 186 nM
Compound 3: middle estimate off by 1.6-fold (0.21 log units), on the high side, within the range that was stated.
By their numbers in this assay, from the lowest: compound 1; then compounds 3 and 2 (each within the scatter of the next).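

Among the compounds shown here, the exchange of 4-methoxyphenyl for pyridin-2-yl on the nitrogen is the first measured change of the ring alone at this position, and in this assay it amounts to a 1.5-fold lower number from compound 2 to compound 3 (0.18 log units; within the scatter) and so lies within the scatter, leaving the ring of carbon only and the ring with one hetero atom indistinguishable here. The other new step, a 2.7-fold higher number from compound 1 to compound 3 (0.44 log units; beyond the scatter) on going to (pyridin-2-yl)amino, lies beyond the scatter in the same direction as the earlier step from compound 1, so among these three compounds both groups with a hydrogen on the nitrogen give higher numbers than methyl(phenyl)amino, whichever of the two rings they carry. Nothing measured for these compounds gives a reason for either step.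

Both steps from compound 1 change the methyl on the nitrogen and the ring together, so the compounds shown leave open which of the two accounts for the lower number of compound 1. As far as these compounds go, a plain phenylamino group or a methyl(pyridin-2-yl)amino group would separate the two, and how a pyridin-3-yl ring on the same nitrogen would read also remains open.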